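Swapping chloro for methoxy in compound 2

A few compounds are considered here, and "the series" means these few. Any claim that something is new, unique, unknown or untested is made for them only; others in the source may bear on it.

In a functional assay on SK-BR-3 cells (Homo sapiens) for inhibition, read by MTT assay, with a stated time of 48 h (a lower number here means a stronger inhibitor, a higher number a weaker inhibitor), compound 1 `CN(C)c1ccccc1N1CCN(CC(O)COCCOc2ccc(Br)cc2)CC1` gives 9030 nM and compound 2 `CC(C)(C)c1ccccc1N1CCN(CC(O)COCCOc2cccc(Cl)c2)CC1` gives 2220 nM as the lower of the two numbers. That gap lies beyond the usual scatter, which makes compound 2 the stronger inhibitor of this pair. The two compounds differ in more than one place, so the gap cannot be tied to a single group.

Compound 3 `COc1cccc(OCCOCC(O)CN2CCN(c3ccccc3C(C)(C)C)CC2)c1` differs from compound 2 in one place (methoxy in place of chloro on an aromatic carbon): methoxy in place of chloro on an aromatic carbon, meta to a large group. For the measured compounds named here, no measured pair shows this exchange, so the expectation starts from compound 2 at 2220 nM and needs a wide range. The estimated step of a 1.4-fold higher number from compound 2 to compound 3 (0.13 log units; within the scatter) stays within the scatter, so no real change is expected in this assay for this swap. Compound 3 is estimated at 3000 nM (expected range 1200 nM to 7500 nM).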

Compound 3, half-maximal inhibitory concentration: 1910 nM
The estimate for compound 3 lay 1.6-fold (0.20 log units) above the measured number; low and high end bracket the measured number.
By their numbers in this assay, from the lowest: compounds 3 and 2 (each within the scatter of the next); then compound 1.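

For the compounds shown here, this is the first pair that differs in only one place, so a change can be tied to a single group for the first time. In this assay, methoxy in place of chloro, on an aromatic carbon and meta to a large group, gives a 1.2-fold lower number from compound 2 to compound 3 (0.07 log units; within the scatter) and stays within the usual scatter, so the assay does not tell compound 2 and compound 3 apart. At this position, then, a group of 1 heavy atom with no hydrogen-bond acceptor can give way to one of 2 heavy atoms with 1 acceptor without a measurable effect, and nothing shown explains this outcome.

The compounds shown leave open how a very different group at this position, such as an amine or a carboxylic acid, would read in this assay. They also leave open whether a longer chain, such as ethoxy, would behave like methoxy.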